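The source may report more compounds than this note shows. Statements on the series, on what has been measured and on what is new or still open speak of the compounds shown alone.

Going by the values given here, compound 3 `Cn1c(-c2ccc(Cl)cc2)c(CCC(=O)N2CCC(O)(Cc3ccccc3)CC2)c2cc(-n3cccc3)ccc21` gives 2.3 nM in an assay on CHO cells for displacement of a labelled ligand from Substance-P receptor (Homo sapiens) (on this read-out lower numbers stand for stronger inhibition and higher numbers for weaker inhibition), the highest of the three numbers measured so far; compound 1 `Cn1c(-c2ccc(Cl)cc2)c(CCC(=O)N2CCC(O)(Cc3ccccc3)CC2)c2cc(Cl)ccc21` gives 0.16 nM and compound 2 `Cn1c(-c2ccc(Cl)cc2)c(CCC(=O)N2CCC(O)(Cc3ccccc3)CC2)c2cc(Br)ccc21` gives 0.22 nM. Compound 4 `Cn1c(-c2ccc(Cl)cc2)c(CCC(=O)N2CCC(O)(Cc3ccccc3)CC2)c2cc(N3CCCCC3)ccc21` differs from compound 3 in one place: piperidin-1-yl in place of 1H-pyrrol-1-yl on an aromatic carbon. The measured steps that touch this position are a 14-fold higher number from compound 1 to compound 3 (1.16 log units; beyond the scatter) and a 10-fold higher number from compound 2 to compound 3 (1.02 log units; beyond the scatter), both large, showing that this position responds strongly to what sits there. Among the compounds with values here, no measured step exchanges one nitrogen-linked ring for another, so the direction is uncertain; a change within the scatter or a modest further rise is expected, a 1.5-fold higher number from compound 3 to compound 4 (0.18 log units; within the scatter). Compound 4 is therefore expected to give 3.5 nM in this assay, with a range from 1 nM to 12 nM.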

Compound 4, half-maximal inhibitory concentration: 3.3 nM
For compound 4 the middle estimate is 1.1-fold (0.03 log units) above the measured one; the measured number falls inside the stated range.
By their numbers in this assay, from the lowest: compounds 1 and 2 (each within the scatter of the next); then compounds 3 and 4 (each within the scatter of the next).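

In this assay, replacing the five-membered aromatic ring with the six-membered non-aromatic ring gives a 1.4-fold higher number from compound 3 to compound 4 (0.16 log units; within the scatter) and so does not separate these two nitrogen-linked rings at this place. Piperidin-1-yl stays apart from both halogens, like 1H-pyrrol-1-yl, with a 15-fold higher number from compound 2 to compound 4 (1.18 log units; beyond the scatter) and a 21-fold higher number from compound 1 to compound 4 (1.31 log units; beyond the scatter) as large steps. The gap seen with the halogens therefore holds whether or not the nitrogen-linked ring is aromatic.

From the compounds shown here alone, whether an open-chain amine such as dimethylamino, or a methoxy group, would fall with the halogens or with the rings remains open. Nothing at hand gives a reason for the gap between the halogens and the rings.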